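The source may hold more compounds than are shown below. What is called first, only, known or untested is meant among the compounds shown, and "the series" means these compounds.

Compound 1 `Cc1c2cc[n+](C)cc2c(C)c2c3c([nH]c12)C=CC(=O)[C@@]31O[C@@H]2[C@H](O1)[C@@H](CO)O[C@H]2n1cnc2c(N)ncnc21` is the starting point. In a functional assay on L1210 cells (Mus musculus) for cytotoxicity (on this read-out lower numbers stand for stronger inhibition and higher numbers for weaker inhibition), compound 1 gives 0.8 uM, the lowest of the two numbers shown. Compound 3 `Cc1c2cc[n+](C)cc2c(C)c2c3c([nH]c12)C=CC(=O)[C@@]31O[C@@H]2[C@H](O1)[C@@H](COP(=O)(O)O)O[C@H]2n1ccc(=O)[nH]c1=O` sits nearest, at 1.1 uM in this assay, and that gap lies within the usual scatter. Compound 2 `Cc1c2cc[n+](C)cc2c(C)c2c3c([nH]c12)C=CC(=O)[C@@]31O[C@@H]2[C@H](O1)[C@@H](COP(=O)(O)O)O[C@H]2n1cnc2c(N)ncnc21` yields only a limit in this assay, > 0.8 uM.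

Two measured steps surround this set. The step from compound 1 to compound 2 is a number no lower from compound 1 to compound 2 (the limit leaves the size open): a group of 4 heavy atoms enters in place of a hydrogen atom on an oxygen on a saturated carbon. The step from compound 2 to compound 3 is a step that the limit leaves unreadable from compound 2 to compound 3, an exchange of the group on a saturated ring carbon. Neither step can be sized because the limit of > 0.8 uM in this assay, at which 1 of the 3 values shown sits, hides the true number for compound 2.

Compound 4 `Cc1c2cc[n+](C)cc2c(C)c2c3c([nH]c12)C=CC(=O)[C@@]31O[C@@H]2[C@H](O1)[C@@H](CO)O[C@H]2n1ncc(=O)[nH]c1=O` is not yet measured. It differs from compound 1 in a group of 8 heavy atoms (3 carbon, 3 nitrogen, 2 oxygen; one six-membered aromatic ring with 3 hetero atoms) in place of a group of 10 heavy atoms (5 carbon, 5 nitrogen; one five-membered aromatic ring with 2 hetero atoms, one six-membered aromatic ring with 2 hetero atoms), on a saturated ring carbon. Compounds 1 and 3 show that a different group on that saturated ring carbon, together with the added group of 4 heavy atoms, still left a number within the scatter. From this, compound 4 is expected to stay close to compound 1, with a step of a 1.3-fold higher number from compound 1 to compound 4 (0.10 log units; within the scatter) in this assay. The estimate for compound 4 is 1 uM, expected to fall between 0.4 uM and 2.5 uM.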

Compound 4, concentration for 50% inhibition: > 3 uM
Compound 4: no number, only a limit (the forecaster's own chance of this, stated with the estimate: 15%); middle value at least 3.0-fold (0.47 log units) away from the limit.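

This result gives the first readable step from a change at this saturated ring carbon alone, with the hydroxymethyl group left in place. In this assay, an at least 3.7-fold higher number from compound 1 to compound 4 (0.57 log units; beyond the scatter), so the group on this carbon is not interchangeable: swapping the group with a five-membered and a six-membered aromatic ring for one six-membered aromatic ring with 3 hetero atoms weakens inhibition beyond the scatter. The earlier steps shown here that involve compound 2 cannot be read, and compound 3 differs from compound 1 in two places, so neither could show this exchange on its own.

The real size of the loss stays unknown, as compound 4 gives only a limit and not a number: the limit of > 3 uM in this assay, at which 1 of the 4 values shown sits.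

Still open, from the compounds shown here alone, is whether the loss belongs to this particular ring or to any group that lacks the fused aromatic pair of compound 1, and a six-membered aromatic ring carrying an amine in place of a carbonyl, set on the same carbon, would help to separate the two.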